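A few compounds are considered here, and "the series" means these few. Any claim that something is new, unique, unknown or untested is made for them only; others in the source may bear on it.

Of the compounds shown here, two have been measured in a functional assay on CHO cells for agonist activity at hydroxycarboxylic acid receptor 1 (Homo sapiens), read by cAMP accumulation; on this read-out higher numbers stand for an effect only at larger amounts of compound and lower numbers for an effect already at smaller amounts. Compound 1 `CN1CCC(S(=O)(=O)c2ccc3nc(NC(=O)NC(=O)c4cc(-n5cccn5)ccc4Cl)sc3c2)CC1` gives 7000 nM in this assay, while compound 2 `CCOc1cc(Cl)c(C(=O)NC(=O)Nc2nc3ccc(CN4CCN(C)CC4)cc3s2)cc1N1CCCC1` gives 13 nM, the lowest of the two numbers, with a gap to compound 1 that lies beyond the scatter. Compound 3 `CCOc1ccc(C(=O)NC(=O)Nc2nc3ccc(CN4CCN(C)CC4)cc3s2)c(Cl)c1` differs from compound 2 in one place: hydrogen in place of pyrrolidin-1-yl on an aromatic carbon. Among the compounds with values here, no measured pair shows this change, so the size of the step from compound 2 to compound 3 in this assay is open; a moderate rise in the number, beyond the scatter, is expected. The expected step is a 4.6-fold higher number from compound 2 to compound 3 (0.66 log units; beyond the scatter). For compound 3 the estimate is 60 nM, with a range from 15 nM to 300 nM.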

Compound 3, half-maximal effective concentration in the hydroxycarboxylic acid receptor 1 assay: 560 nM
Compound 3: middle estimate off by 9.3-fold (0.97 log units), on the low side; the measured number lies above the stated range.
By their numbers in the hydroxycarboxylic acid receptor 1 assay, from the lowest: compound 2; then compound 3; then compound 1.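

With the shared core and the ethoxy and chloro groups held constant, the position ortho to an ethoxy group proves highly sensitive in the hydroxycarboxylic acid receptor 1 assay: hydrogen in place of pyrrolidin-1-yl gives a 43-fold higher number from compound 2 to compound 3 (1.63 log units; beyond the scatter). Within the data shown here, this large loss exceeds what the earlier compounds indicated for this position. In a physicochemical assay for lipophilicity, at pH 7.4 (on this read-out higher numbers stand for higher lipophilicity and lower numbers for lower lipophilicity), compound 2 gives 4 and compound 3 gives 3.4. In the physicochemical assay, the same change also lowers lipophilicity: the measured distribution coefficient of compound 2, 4, and of compound 3, 3.4, a number 0.60 log units lower (beyond the scatter)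

A single pair cannot separate the role of pyrrolidin-1-yl itself from that of lipophilicity. From the compounds shown here alone, whether a dimethylamino group or a methoxy group at this position would serve equally remains open.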